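A few compounds are considered here, and "the series" means these few. Any claim that something is new, unique, unknown or untested is made for them only; others in the source may bear on it.

Compound 1, `O=C(Nc1ccc(-n2ccc3c(NC(=O)c4ccccc4)ncnc32)cc1)Nc1ccc(Cl)c(C(F)(F)F)c1`: 4600 nM
Compound 2, `Nc1ncnc2c1ccn2-c1ccc(NC(=O)c2ccc(Cl)c(C(F)(F)F)c2)cc1`: 2900 nM
Compound 3, `O=C(Nc1ccc(-n2ccc3c(NC(=O)c4ccccc4)ncnc32)cc1)Nc1cccc(C(F)(F)F)c1`: 9500 nM

These three values come from a functional assay on A375P cells (Homo sapiens) for antiproliferative activity, read by MTT assay, with a stated time of 24 h; on this read-out lower numbers stand for stronger inhibition and higher numbers for weaker inhibition. Compound 1 and compound 3 share one core and differ in a single place: hydrogen in place of chloro on an aromatic carbon. That change produced a 2.1-fold higher number from compound 1 to compound 3 (0.31 log units; beyond the scatter), so the compound without the chloro gave the weaker result. Compound 2 is built on a different core; how the two cores differ is not broken down here, and the numbers for compound 1 and compound 2 lie within the usual scatter of each other.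

Compound 4, `Nc1ncnc2c1ccn2-c1ccc(NC(=O)c2cccc(C(F)(F)F)c2)cc1`, has not yet been measured. It stands to compound 2 exactly as compound 3 stands to compound 1: hydrogen in place of chloro on an aromatic carbon, the same change at the same kind of place. Because the earlier step read a 2.1-fold higher number from compound 1 to compound 3 (0.31 log units; beyond the scatter), a step of similar size is expected here, so the estimated step is a 2.1-fold higher number from compound 2 to compound 4 (0.32 log units; beyond the scatter). Compound 4 is therefore expected to give about 6000 nM in this assay, with the likely range running from 3000 nM to 12000 nM.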

Compound 4, half-maximal inhibitory concentration: 9700 nM
The estimate for compound 4 lay 1.6-fold (0.21 log units) below the measured number; the range from low to high includes it.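

Taking away the chloro that sits ortho to a trifluoromethyl group weakened the result on the core of compound 2 as well, and in this assay this change gave a 3.3-fold higher number from compound 2 to compound 4 (0.52 log units; beyond the scatter). Set beside the earlier step, the change points the same way on both cores, and the two steps do not differ in size by more than repeated measurements would allow: the same change on two cores in this assay, a 2.1-fold higher number (0.31 log units; beyond the scatter) from compound 1 to compound 3 and a 3.3-fold higher number (0.52 log units; beyond the scatter) from compound 2 to compound 4, 1.6-fold (0.21 log units) apart, within the scatter of two such steps This shows that the loss on removing the chloro carried over between these two cores, but two cores are a small sample, so it neither shows that a third core would behave alike nor explains why the chloro matters.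

The compounds shown carry only chloro or hydrogen at this place, so it stays open how a fluoro, a methoxy group or a nitrile there would read in this assay. Also open, as far as these compounds go, is what would happen if the trifluoromethyl group itself gave way to a methyl group or an amine.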